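Thiophen-3-yl Gives Way to 3-Hydroxyphenyl in an Inert Series

This account rests on a few compounds, and the source may have more. Where it says the series, first, only, none or still open, it means among the compounds named here.

Of the compounds shown here, three sharing one core have been tested in an ADME assay on Raji cells (Homo sapiens) for cytotoxicity, read by CellTiter-Glo and resazurin assay, with a stated time of 72 h; on this read-out lower numbers stand for an effect already at smaller amounts and higher numbers for an effect only at larger amounts of compound. Compound 1 `CC(C)N(Cc1cccc(OCCCCCC(=O)O)c1)C(=O)c1ccccc1` carries only hydrogen at the position of interest, and in this assay compound 1 gives > 26000 nM, which is a limit of the assay rather than a number. Compound 2 `CC(C)N(Cc1cccc(OCCCCCC(=O)O)c1)C(=O)c1ccc(-c2cccc3ccccc23)cc1` adds a naphthalen-1-yl group, and in this assay compound 2 gives > 26000 nM, again a limit. Compound 3 `CC(C)N(Cc1cccc(OCCCCCC(=O)O)c1)C(=O)c1ccc(-c2ccsc2)cc1` carries thiophen-3-yl instead, and in this assay compound 3 gives > 26000 nM, also a limit. Because of the limit of > 26000 nM in this assay, at which 3 of the 3 values shown sit, none of the steps can be sized: a step that the two limits leave unreadable from compound 1 to compound 2, a step that the two limits leave unreadable from compound 1 to compound 3 and a step that the two limits leave unreadable from compound 2 to compound 3 all stay unreadable. Compound 3 therefore stands at the same limit as the other two, with no ranking possible among them.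

Compound 4 `CC(C)N(Cc1cccc(OCCCCCC(=O)O)c1)C(=O)c1ccc(-c2cccc(O)c2)cc1` is the next compound to be tested. The change is 3-hydroxyphenyl in place of thiophen-3-yl on an aromatic carbon. Within the data shown here, no measured step bears on this exchange directly, so the expectation rests only on the fact that every compound so far has sat at the limit. Compound 4 is expected to show 40000 nM in this assay, with a likely range from 15000 nM to 100000 nM. The expected step is a step that the limit leaves unreadable from compound 3 to compound 4, which means no effect beyond the scatter, and most probably another limit.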

Compound 4, half-maximal effective concentration: > 26000 nM
Compound 4: only a limit was reported (the forecaster's own chance of this, stated with the estimate: 85%); the middle value lies beyond the limit too.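

No step from compound 1, compound 2 or compound 3 to compound 4 can be read, because all four compounds stop at the same limit of the assay: the limit of > 26000 nM in this assay, at which 4 of the 4 values shown sit.

The compounds shown leave open whether any group at this place gives an effect in this assay, and how hydrogen, naphthalen-1-yl, thiophen-3-yl and 3-hydroxyphenyl truly differ.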